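A Thiophene in Place of the Fluorophenyl Group

The source may report more compounds than this note shows. Statements on the series, on what has been measured and on what is new or still open speak of the compounds shown alone.

Compound 1, `Brc1cn2ccnc2c(-c2ccc3ncn(C4CCCCC4)c3c2)n1`: 10.2%
Compound 2, `Fc1ccc(-c2cn3ccnc3c(-c3ccc4ncn(C5CCCCC5)c4c3)n2)cc1`: 9.82%

In a functional assay on SK-MEL-2 cells (Homo sapiens) for inhibition, read by sulforhodamine B assay, with a stated time of 48 h, tested at 10 uM (a lower number here means less inhibition, a higher number more inhibition at the concentration tested (going by the name of the read-out)), compound 1 gives 10.2% and compound 2 gives 9.82%; the two numbers lie within the scatter of each other, so compound 2 cannot be told apart from compound 1 on these figures.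

Compound 3, `c1cn2cc(-c3ccsc3)nc(-c3ccc4ncn(C5CCCCC5)c4c3)c2n1`, is not yet measured. Its change from compound 2 is thiophen-3-yl in place of 4-fluorophenyl on an aromatic carbon. Among the compounds with values here, the one measured step at this same aromatic carbon, a number 0.4 percentage points lower from compound 1 to compound 2 (within the scatter), left the read-out unchanged. Compound 3 is therefore expected to show a number 0.2 percentage points higher from compound 2 to compound 3 (within the scatter), no step beyond the scatter. Compound 3 is estimated to give 10%, with a range from 0% to 25%.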

Compound 3, a percentage reported as inhibition, at one concentration (the size of the read-out at that concentration, not a potency): 3.68%
The estimate for compound 3 lay 6.3 percentage points above the measured number; measured number inside the range.
By their numbers in this assay, from the lowest: compounds 3, 2 and 1 (each within the scatter of the next).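

In this assay, a five-membered thiophen-3-yl ring on this aromatic carbon gives a number 6.1 percentage points lower from compound 2 to compound 3 (within the scatter) and a number 6.5 percentage points lower from compound 1 to compound 3 (within the scatter). Bromo, 4-fluorophenyl and thiophen-3-yl therefore cannot be told apart at this position, even though the last brings a different ring size and a sulfur atom. No measurement on hand explains these numbers. From the compounds shown here alone, it remains open whether an amine or a carboxylic acid on this carbon would move the read-out beyond the scatter. Changes elsewhere, such as replacing the cyclohexyl group, also remain open.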